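A few compounds are considered here, and "the series" means these few. Any claim that something is new, unique, unknown or untested is made for them only; others in the source may bear on it.

In an ADME assay on BJ cells (Homo sapiens), read by MTT assay, with a stated time of 72 h (a higher number here means a weaker inhibitor, a lower number a stronger inhibitor), compound 2 (`CNc1ncnc2c1c(-c1ccoc1)cn2[C@@H]1O[C@H](CO)[C@@H](O)[C@H]1O`) gives 96300 nM and sits level, within the scatter, with compound 1 (`CSc1ncnc2c1c(-c1ccoc1)cn2[C@@H]1O[C@H](CO)[C@@H](O)[C@H]1O`), which gives 98800 nM in the same test. For the measured compounds named here, the only measured step (a 1.0-fold lower number from compound 1 to compound 2 (0.01 log units; within the scatter)) exchanges methylsulfanyl for methylamino, at a different place from the next change, so it offers no direct guide. Compound 3 (`CNc1ncnc2c1c(-c1cc3ccccc3o1)cn2[C@@H]1O[C@H](CO)[C@@H](O)[C@H]1O`) differs from compound 2 by 1-benzofuran-2-yl in place of furan-3-yl on an aromatic carbon on an aromatic carbon of a five-membered aromatic ring with 1 nitrogen. Going by the values given here, with no measured step at that place, no shift beyond the scatter is expected in this assay, and the expected step (a 1.6-fold lower number from compound 2 to compound 3 (0.21 log units; within the scatter)) is small. Compound 3 is estimated at 60000 nM with an expected range from 15000 nM to 150000 nM in this test.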

Compound 3, half-maximal inhibitory concentration: 75600 nM
Estimate against measurement, compound 3: 1.3-fold (0.10 log units) below, within the range that was stated.
By their numbers in this assay, from the lowest: compounds 3, 2 and 1 (each within the scatter of the next).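

In this assay, the exchange of furan-3-yl for 1-benzofuran-2-yl gives a 1.3-fold lower number from compound 2 to compound 3 (0.11 log units; within the scatter), so adding a six-membered aromatic ring of carbon only at this place leaves the number within the scatter. For the compounds shown here, this is the first reading at this position on the five-membered aromatic ring with 1 nitrogen, since the earlier step lay elsewhere. No evidence bears on this result. The compounds shown leave open whether an amine or a carboxylic acid on the 1-benzofuran-2-yl group would shift the number beyond the scatter.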